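Fluoro in Place of Methyl: What Compound 4 May Give

This account rests on a few compounds, and the source may have more. Where it says the series, first, only, none or still open, it means among the compounds named here.

Measured compounds:
Compound 1, `CCc1nc2ccccc2c(=O)n1NC(=O)Nc1ccc([N+](=O)[O-])cc1`: 41%
Compound 2, `O=C(Nc1ccc(F)cc1)Nn1c(-c2ccccc2)nc2ccccc2c1=O`: 54%
Compound 3, `CCc1nc2ccccc2c(=O)n1NC(=O)Nc1ccc(C)cc1`: 55%

Of the compounds shown here, three have been tested in a functional assay on the whole organism (strain albino) with Mus musculus as the target, at a dose of 100 mg/kg by the intraperitoneal route; a lower number here means less inhibition, a higher number more inhibition at the dose given (going by the name of the read-out). Compound 3 gives 55%, the highest of the three numbers, although compound 2 sits within the scatter of it with 54%, so no order between compound 2 and compound 3 can be claimed. Compound 1, with 41%, lies furthest below. Within the data shown here, the one measured step, a number 14 percentage points higher from compound 1 to compound 3 (beyond the scatter), shows that methyl in place of nitro on an aromatic carbon raised the number modestly but beyond the scatter.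

The unmeasured compound 4, `CCc1nc2ccccc2c(=O)n1NC(=O)Nc1ccc(F)cc1`, differs from compound 3 in one place: fluoro in place of methyl on an aromatic carbon. Among the measured compounds shown here, no measured step tests this exact exchange. The only point of reference is compound 2, which carries a fluoro at the same place on a different core and gives a number within the scatter of compound 3. On that basis a step in this assay of no more than the scatter is expected, a number 5 percentage points lower from compound 3 to compound 4 (within the scatter). Compound 4 is therefore estimated at 50%, with a range from 38% to 62%.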

Compound 4, a percentage reported as inhibition, in the whole organism at one dose (the size of the read-out at that dose, not a potency): 51%
For compound 4 the middle estimate is 1 percentage points below the measured one; measured number inside the range.
By their numbers in this assay, from the lowest: compounds 1, 4, 2 and 3 (each within the scatter of the next, the first and the last beyond it).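

At this position on the aromatic ring, para to a large group, fluoro in place of methyl gives in this assay a number 4 percentage points lower from compound 3 to compound 4 (within the scatter), so on the shared core the two groups cannot be told apart by this read-out. Among these compounds, with the 4-fluorophenyl group kept, ethyl in place of phenyl on the core gives a number 3 percentage points lower from compound 2 to compound 4 (within the scatter), a first direct reading of that exchange, and it too stays within the scatter. Fluoro in place of nitro gives a number 10 percentage points higher from compound 1 to compound 4 (within the scatter), while methyl in place of nitro gave a number 14 percentage points higher from compound 1 to compound 3 (beyond the scatter), so only the methyl step clears the scatter, although the numbers of compound 3 and compound 4 cannot be separated, and nothing given here bears on why the numbers fall this way.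

The compounds shown leave open whether an amine, a methoxy group or a carboxylic acid at this position would leave the number where methyl and fluoro put it. They also leave open what a longer chain in place of the ethyl on the core would do, and a reading at one dose says nothing about potency.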